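The source may report more compounds than this note shows. Statements on the series, on what has been measured and on what is new or still open speak of the compounds shown alone.

Measured so far in a functional assay on the whole organism (Tail, strain ICR) with Mus musculus as the target, in the tail flick test, with a stated time of 30 min, at a dose of 25 umol/kg by the oral route; a higher number here means a stronger effect of the compound at the dose given, a lower number a weaker effect:

compound 1, `C[C@@H](O)[C@H](NC(=O)CN(c1nc(Cl)nc2[nH]cnc12)C1CC1)C(=O)OCc1ccccc1`: 21.9%
compound 2, `NC(=O)C[C@H](NC(=O)CN(c1nc(Cl)nc2[nH]cnc12)C1CC1)C(=O)O`: 29.7%
compound 3, `C[C@@H](O)[C@H](NC(=O)CN(c1nc(Cl)nc2[nH]cnc12)C1CC1)C(=O)O`: 18.6%

Compound 3 sits at the low end of these three numbers. Its value lies within the scatter of that of compound 1, so the two cannot be told apart, while compound 2 stands above it by a margin beyond the scatter. The two measured steps that lead to compound 3 are a number 3.3 percentage points lower from compound 1 to compound 3 (within the scatter) and a number 11.1 percentage points lower from compound 2 to compound 3 (beyond the scatter); the second of these changes the same place that is changed next.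

Compound 4, `C[C@H](NC(=O)CN(c1nc(Cl)nc2[nH]cnc12)C1CC1)C(=O)O`, is not yet measured. It differs from compound 3 by methyl in place of 1-hydroxyethyl on a saturated chain carbon bound to an amide-type nitrogen and a carbonyl carbon. The step from compound 2 to compound 3 already swapped the group on this carbon and moved the number by a modest amount, so a change at this position can matter; the step from compound 1 to compound 3 stayed within the scatter. Within the data shown here, with only one step at this place to go by, and the groups involved being small, compound 4 is expected to stay close to compound 3, with an estimated a number 1.4 percentage points higher from compound 3 to compound 4 (within the scatter) that does not clearly exceed the scatter. The estimate for compound 4 in this assay is 20%, between 8% and 32%.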

Compound 4, a percentage reported as activity, at one dose (the size of the read-out at that dose, not a potency): 48.1%
The estimate for compound 4 lay 28.1 percentage points below the measured number; the measured number lies above the stated range.
By their numbers in this assay, from the lowest: compounds 3, 1 and 2 (each within the scatter of the next, the first and the last beyond it); then compound 4.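

In this assay, methyl in place of 1-hydroxyethyl on the saturated chain carbon bound to an amide-type nitrogen and a carbonyl carbon gives a number 29.5 percentage points higher from compound 3 to compound 4 (beyond the scatter), and hydrogen in place of carbamoyl, which turns carbamoylmethyl into that same methyl, gives a number 18.4 percentage points higher from compound 2 to compound 4 (beyond the scatter). The earlier compounds shown here showed only a gap between 1-hydroxyethyl and carbamoylmethyl at this carbon; the result now shows that methyl reads above both groups, so the position spans a wider range of read-outs than that gap suggested, and removing the hydroxyl-bearing or the carbamoyl-bearing part raises the number in each case. No measurement is available that explains this rise, so its origin stays unassigned.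

The compounds shown leave open whether the trend continues with a bare hydrogen on this carbon, or whether an ethyl, an isopropyl or a longer unbranched chain reads like methyl, and how a chain ending in an amine or a carboxylic acid would compare. They also leave open whether a benzyl ester on the carboxylic acid of the methyl compound would change the number, since that ester is seen here only with 1-hydroxyethyl at this carbon.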